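Diaryl urea of compound 1 exchanged for a benzamide

The source may hold more compounds than are shown below. What is called first, only, known or untested is meant among the compounds shown, and "the series" means these compounds.

Among the compounds with values here, in a functional assay on RPMI-8226 cells (Homo sapiens) for inhibition, read by sulforhodamine B assay, with a stated time of 48 h (on this read-out lower numbers stand for stronger inhibition of growth and higher numbers for weaker inhibition of growth), compound 1 `COc1cc(-c2nn(-c3cccc(NC(=O)Nc4ccc(Cl)c(Cl)c4)c3)cc2-c2ccncc2)ccc1Cl` gives 3260 nM and is the only compound of the three with a number rather than a limit. Compound 2 `O=C(Nc1cccc(-n2cc(-c3ccncc3)c(-c3ccc(Cl)c(O)c3)n2)c1)Nc1ccc(Cl)c(Cl)c1` reaches only a limit, > 32500 nM, in this assay. Compound 3 `O=C(Nc1cccc(-n2cc(-c3ccncc3)c(-c3ccc(Cl)c(O)c3)n2)c1)Nc1cc(C(F)(F)F)cc(C(F)(F)F)c1` likewise reaches only a limit, > 50000 nM, in this assay. Within the data shown here, the one step between measured compounds that differ in a single place, an at least 9.9-fold higher number from compound 1 to compound 2 (0.99 log units; beyond the scatter), concerns the oxygen on the aromatic ring and is pinned to the limit of > 32500 nM in this assay, at which 1 of the 3 values shown sits, so it bears on a different part of the molecule than the change now considered.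

Compound 4 `COc1cc(-c2nn(-c3cccc(NC(=O)c4ccccc4)c3)cc2-c2ccncc2)ccc1Cl` differs from compound 1 in one place: phenyl in place of (3,4-dichlorophenyl)amino on a carbonyl carbon. Among the measured compounds shown here, no measured step touches the carbonyl end of compound 1, so there is nothing to set the size of the step directly; the record shows only that removing a methyl elsewhere took compound 2 to a limit. Compound 4 loses the hydrogen-bond donor of the (3,4-dichlorophenyl)amino group, and the estimate for it is a weaker value, with a 3.7-fold higher number from compound 1 to compound 4 (0.57 log units; beyond the scatter) expected in this assay, and a real chance that only a limit is returned. Compound 4 is therefore expected to give about 12000 nM, with a range from 3000 nM to 40000 nM.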

Compound 4, concentration for total growth inhibition: > 100000 nM
Compound 4 ended at the assay's limit; the forecaster's own chance of this, stated with the estimate: 30%; middle value at least 8.3-fold (0.92 log units) away from the limit.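

In this assay, within the data shown here, exchanging (3,4-dichlorophenyl)amino for phenyl on the carbonyl carbon gives an at least 30-fold higher number from compound 1 to compound 4 (1.48 log units; beyond the scatter), the only measured step at this end of the molecule. Compound 4 returns > 100000 nM, which is a limit and not a number, and the size of the step is tied to it: the limit of > 100000 nM in this assay, at which 1 of the 4 values shown sits. With this result, both single changes shown from compound 1, one at the oxygen on the aromatic ring and one at the carbonyl carbon, end at a limit, so the carbonyl end, which the earlier compounds left untested, also responds strongly to change in this assay.

The change to compound 4 removes the amino nitrogen and both chlorine atoms together, and the compounds shown cannot say how much of the step belongs to each. On these data alone, whether a phenylamino group on the carbonyl carbon, which keeps the nitrogen without the chlorines, or a 3,4-dichlorophenyl group on it, which keeps the chlorines without the nitrogen, would retain a measurable value remains open.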